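The compounds below may be only part of what the source reports. "The series", "measured", "known", "first", "only" and "open" are said of these compounds alone.

Working notes on the series.

Three compounds are in hand. Compound 1 `N[C@@H](CC(=O)OC[C@H]1O[C@@H](n2cc(F)c(=O)[nH]c2=O)C[C@@H]1O)C(=O)O` gives 29300000 nM in a functional assay on MDA-MB-231 cells (Homo sapiens) for inhibition, read by MTT assay, with a stated time of 24 h; a lower number here means a stronger inhibitor of growth, a higher number a weaker inhibitor of growth. Compound 2 `N[C@@H](CCC(=O)O[C@H]1C[C@H](n2cc(F)c(=O)[nH]c2=O)O[C@@H]1CO)C(=O)O` gives 34900000 nM in this assay. Compound 3 `N[C@@H](CCC(=O)OC[C@H]1O[C@@H](n2cc(F)c(=O)[nH]c2=O)C[C@@H]1O)C(=O)O` gives 38300000 nM in this assay. All three numbers sit close together, and no value among them is set apart from the others by more than the usual scatter.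

One matched change is measured once: from compound 3 to compound 1 the change is amino(carboxy)methyl in place of 2-amino-2-carboxyethyl on a saturated chain carbon bound to a carbonyl carbon, and the step it made is a 1.3-fold lower number from compound 3 to compound 1 (0.12 log units; within the scatter). The difference between the cores of compound 2 and compound 3 is not broken down here; the two are built from the same atoms joined differently, and their two numbers lie within the scatter of one another.

Compound 4 `N[C@@H](CC(=O)O[C@H]1C[C@H](n2cc(F)c(=O)[nH]c2=O)O[C@@H]1CO)C(=O)O` is not yet measured. It stands to compound 2 as compound 1 stands to compound 3: the change is amino(carboxy)methyl in place of 2-amino-2-carboxyethyl on a saturated chain carbon bound to a carbonyl carbon, the same change at the same place. Going by the values given here, with only one measured example of this change, the step from compound 2 to compound 4 in this assay is expected to be about as small as the one from compound 3 to compound 1, so the expected step is a 1.2-fold lower number from compound 2 to compound 4 (0.10 log units; within the scatter), resting on compound 2 at 34900000 nM and on the step of a 1.3-fold lower number from compound 3 to compound 1 (0.12 log units; within the scatter). For compound 4 the estimate in this assay is 28000000 nM, expected to fall between 14000000 nM and 56000000 nM.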

Compound 4, concentration for 50% growth inhibition: 37600000 nM
For compound 4 the middle estimate is 1.3-fold (0.13 log units) below the measured one, and the stated range covers the measured number.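

In this assay, amino(carboxy)methyl in place of 2-amino-2-carboxyethyl on a saturated chain carbon bound to a carbonyl carbon gives a 1.1-fold higher number from compound 2 to compound 4 (0.03 log units; within the scatter), a step within the scatter. Set beside the earlier step, the same change on the two cores shows no difference that can be told from the scatter: the same change on two cores in this assay, a 1.3-fold lower number (0.12 log units; within the scatter) from compound 3 to compound 1 and a 1.1-fold higher number (0.03 log units; within the scatter) from compound 2 to compound 4, 1.4-fold (0.15 log units) apart, within the scatter of two such steps. This shows that, on these two cores, the change leaves the read-out within the scatter on each and that the two steps agree within the scatter; it does not show that the opposite signs of the two steps are real, that the change would stay this small on any other core, or that the chain length plays no part in a series whose values all sit this close together.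

The compounds shown leave open whether anything at this ester position moves the number beyond the scatter, for instance a longer chain, an amide in place of the ester, or an amine without the carboxylic acid. They also leave open how a compound with a free hydroxyl at both sugar positions, carrying no amino acid ester at all, compares in this same read-out.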